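Amide nitrogen changes: from compound 2 to compound 3

A few compounds are considered here, and "the series" means these few. Any claim that something is new, unique, unknown or untested is made for them only; others in the source may bear on it.

Compound 1 `CCN(CC)CCNC(=O)c1ccc(C(CC)(CC)c2ccc(OCCC(O)(CC)CC)c(C)c2)n1CC`: 3350 nM
Compound 2 `CCOc1ccc(NC(=O)c2ccc(C(CC)(CC)c3ccc(OCCC(O)(CC)CC)c(C)c3)n2CC)cc1`: > 50000 nM (a limit, not a number)

Both were read in a functional assay on PC-3 cells (Homo sapiens) for antiproliferative activity, read by MTT assay, with a stated time of 48 h; on this read-out lower numbers stand for stronger inhibition and higher numbers for weaker inhibition. Compound 2 stands at the limit of > 50000 nM in this assay, at which 1 of the 2 values shown sits. Compound 3 `CCC(C)C(NC(=O)c1ccc(C(CC)(CC)c2ccc(OCCC(O)(CC)CC)c(C)c2)n1CC)C(=O)OC` differs from it on an amide-type nitrogen: a group of 9 heavy atoms (7 carbon, 2 oxygen; no ring) in place of a group of 9 heavy atoms (8 carbon, 1 oxygen; one six-membered aromatic ring of carbon only), on an amide-type nitrogen. For the measured compounds named here, the one measured step at that nitrogen is large: an at least 14-fold higher number from compound 1 to compound 2 (1.17 log units; beyond the scatter). That single step, which ends at a limit, gives only a loose guide. The expected change in this assay is a smaller one towards lower numbers, namely an at least 2.5-fold lower number from compound 2 to compound 3 (0.39 log units; beyond the scatter). Another limit remains possible. For compound 3 the estimate is 20000 nM, with an expected range of 6000 nM to 60000 nM.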

Compound 3, half-maximal inhibitory concentration: > 50000 nM
Compound 3 was reported as a limit; the forecaster's own chance of this, stated with the estimate: 40%; middle value at least 2.5-fold (0.39 log units) away from the limit.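

Compound 3 gives > 50000 nM in this assay, a limit and not a number. With no ring in the group on this amide-type nitrogen, the result is still an at least 14-fold higher number from compound 1 to compound 3 (1.17 log units; beyond the scatter), so a one-ring group such as 4-ethoxyphenyl is not needed to reach the limit. The step from compound 2 to compound 3 cannot be read, and the limit holds both compounds: the limit of > 50000 nM in this assay, at which 2 of the 3 values shown sit.

Still open, as far as these compounds go, is whether the amine in the 2-(diethylamino)ethyl group of compound 1 matters, or only the chain carrying it. A plain alkyl chain without the amine, or a longer chain ending in a diethylamine, would separate the two.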